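A few compounds are considered here, and "the series" means these few. Any claim that something is new, unique, unknown or untested is made for them only; others in the source may bear on it.

Three compounds share a core that joins a pyrimidinedione sulfonamide to an aniline carrying a triazole. Compound 1 `O=c1[nH]cc(S(=O)(=O)Nc2ccccc2-c2cn(-c3cccc(F)c3)nn2)c(=O)[nH]1` was assessed in an ADME assay on L02 cells (Homo sapiens) for cytotoxicity, read by MTT assay, with a stated time of 24 h (on this read-out higher numbers stand for lower toxicity in this test and lower numbers for higher toxicity in this test), and gave "not toxic" (no number reported). Compound 2 `O=c1[nH]cc(S(=O)(=O)Nc2cccc(-c3cn(-c4ccc(Cl)cc4)nn3)c2)c(=O)[nH]1` gave 9860 nM in this assay. Compound 3 `O=c1[nH]cc(S(=O)(=O)Nc2ccc(-c3cn(-c4ccccc4)nn3)cc2)c(=O)[nH]1` was reported in this assay as "not toxic" (no number reported), so no single number stands for it, and the same is true of compound 1; only compound 2 carries a figure in this series.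

Compound 4 `O=c1[nH]cc(S(=O)(=O)Nc2ccc(-c3cn(-c4cccc(Cl)c4)nn3)cc2)c(=O)[nH]1` is the next compound to be run in this assay. It differs from compound 3 in one place: chloro in place of hydrogen on an aromatic carbon. Going by the values given here, no comparable step between measured compounds exists for this change. The closest hint is that compound 2, which also carries a chlorine on its terminal phenyl, sits at 9860 nM, whereas compound 3 at "not toxic" (no number reported) gave no number at all. Given that contrast, a step in this assay toward somewhat higher toxicity than compound 3 is expected, but probably still in the range where the read-out may not resolve a value.

Compound 4 is therefore expected to fall near 20000 nM in this assay, within a range from 5000 nM to 100000 nM, with a real chance that it too is reported only as not toxic.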

Compound 4, half-maximal cytotoxic concentration: 19000 nM
Estimate against measurement, compound 4: 1.1-fold (0.02 log units) above, and the stated range covers the measured number.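

No step can be read from compound 3 to compound 4 in this assay, as compound 3 stands as "not toxic" (no number reported) while compound 4 gives 19000 nM. The compounds shown leave open how large a change phenyl to 3-chlorophenyl brings on this read-out. Nothing measured here bears on a cause for this result.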